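Trimming a Methyl from a Weakly Cytotoxic Series

The compounds below may be only part of what the source reports. "The series", "measured", "known", "first", "only" and "open" are said of these compounds alone.

compound 1 `Cc1cccc(Nc2nc(C)c(C(=O)/C=C/c3ccc(Cl)cc3)s2)c1` — > 25000 nM
compound 2 `COc1cc(/C=C/C(=O)c2sc(Nc3ccc(C)cc3)nc2C)cc(OC)c1OC` — > 25000 nM
compound 3 `Cc1cccc(Nc2nc(C)c(C(=O)/C=C/c3ccccc3Cl)s2)c1` — 24200 nM

In a functional assay on BGC-823 cells (Homo sapiens) for cytotoxicity, read by MTT assay (a lower number here means a stronger inhibitor, a higher number a weaker inhibitor), compound 1 gives > 25000 nM, which is a limit of the assay rather than a measured number. Compound 2 likewise gives only a limit, > 25000 nM. For the measured compounds named here, compound 3 is the one compound with a number, 24200 nM. Going by the values given here, the only step between measured compounds is an at least 1.0-fold lower number from compound 1 to compound 3 (0.01 log units; that floor lies within the scatter); it concerns the chlorophenyl end of the molecule and lies within the scatter, and it is anchored to the limit of > 25000 nM in this assay, at which 2 of the 3 values shown sit, so it says little about the other end.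

Compound 4 `Cc1nc(Nc2ccccc2)sc1C(=O)/C=C/c1ccc(Cl)cc1` differs from compound 1 by hydrogen in place of methyl on an aromatic carbon. Among the compounds with values here, no measured step touches this part of the structure, so nothing measured bears directly on the change. All three measured compounds sit at or near the same weak level, so the expectation is that compound 4 stays in that region, with a step of a number no higher from compound 1 to compound 4 (the limit leaves the size open) that is not expected to exceed the scatter. Compound 4 is therefore estimated at 25000 nM, within a range from 10000 nM to 60000 nM, and it may well again return only a limit.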

Compound 4, half-maximal inhibitory concentration: > 25000 nM
Compound 4 gave a limit, no number; the forecaster's own chance of this, stated with the estimate: 70%; the middle value lies on the limit itself.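

In this assay, for the compounds shown here, compound 4 gives > 25000 nM as a limit and not a number, so no step from compound 1 to compound 4 can be read: the limit of > 25000 nM in this assay, at which 3 of the 4 values shown sit. From the compounds shown here alone, whether changing 3-methylphenyl to phenyl alters cytotoxicity at all remains open.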